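Swapping a Cyanophenyl Tail for Cyclohexyl

A few compounds are considered here, and "the series" means these few. Any claim that something is new, unique, unknown or untested is made for them only; others in the source may bear on it.

Compound 2 `N#Cc1ccc(CCCCCCCCC(=O)N2CCCCC2)cc1` is a long-chain amide carrying a 4-cyanophenyl tail. In a functional assay on PANC-1 cells (Homo sapiens) for cytotoxicity, read by WST assay, with a stated time of 24 h (a lower number here means a stronger inhibitor, a higher number a weaker inhibitor), compound 2 gives > 100000 nM, which is a limit of the assay rather than a number. Compound 1 `O=C(/C=C/CCCCCCc1ccccc1)NCc1ccccc1` likewise gives only a limit, > 100000 nM, in this assay. Compound 3 `O=C(CCCCCCCCc1ccc2ccccc2c1)N1CCCCC1` gives 87000 nM in this assay. Compound 2 thus sits at the limit of > 100000 nM in this assay, at which 2 of the 3 values shown sit. Compound 4 `O=C(CCCCCCCCC1CCCCC1)N1CCCCC1` differs from compound 2 in one place: cyclohexyl in place of 4-cyanophenyl on a saturated chain carbon, eight bonds along the chain from a carbonyl carbon. For the measured compounds named here, no pair of measured compounds here differs in a single place, so no measured step can guide the size of this change. The step from compound 2 to compound 4 is expected to be a step that the limit leaves unreadable from compound 2 to compound 4, nothing beyond the scatter. Compound 4 is therefore estimated at 120000 nM, ranging from 50000 nM to 300000 nM.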

Compound 4, half-maximal inhibitory concentration: > 100000 nM
Compound 4: only a limit was reported; the forecaster's own chance of this, stated with the estimate: 70%; the middle value lies beyond the limit too.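

Compound 2 and compound 4 both stop at a limit of the assay, so no size can be read for putting cyclohexyl in place of 4-cyanophenyl. As far as these compounds go, whether this change alters activity at all stays open.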